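Dichlorophenyl in Place of Nitrophenyl: Still at the Limit

The source may report more compounds than this note shows. Statements on the series, on what has been measured and on what is new or still open speak of the compounds shown alone.

Compound 1 `O=C(Nc1ccc([N+](=O)[O-])cc1OCc1ccccc1)C1CCCCC1` and compound 2 `O=C(Nc1ccc([N+](=O)[O-])cc1OCc1ccccc1)c1ccc([N+](=O)[O-])cc1` share one core. In an assay on SK-BR-3 cells for inhibition of Aromatase (Homo sapiens) (a higher number here means a weaker inhibitor, a lower number a stronger inhibitor), compound 1 reaches only the limit of > 25000 nM. In this assay compound 2 likewise reaches only the limit of > 25000 nM. The step that the two limits leave unreadable from compound 1 to compound 2 therefore cannot be read, and compound 2 stands at that limit, as the limit of > 25000 nM in this assay, at which 2 of the 2 values shown sit, records. Compound 3 `O=C(Nc1ccc([N+](=O)[O-])cc1OCc1ccccc1)c1ccc(Cl)c(Cl)c1` differs from compound 2 by 3,4-dichlorophenyl in place of 4-nitrophenyl on a carbonyl carbon. Within the data shown here, no measured step offers a readable size, so nothing points to a change beyond the scatter in this assay. Compound 3 is expected to give 30000 nM, within 8000 nM to 100000 nM, an expected step that the limit leaves unreadable from compound 2 to compound 3.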

Compound 3, half-maximal inhibitory concentration: > 25000 nM
Compound 3 ended at the assay's limit (the forecaster's own chance of this, stated with the estimate: 80%); the middle value does not contradict the limit.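

No step between compound 1, compound 2 and compound 3 can be read in this assay, as all three stop at one limit: the limit of > 25000 nM in this assay, at which 3 of the 3 values shown sit.

The compounds shown leave open whether any group on this carbonyl carbon would give a readable value.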